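The source may report more compounds than this note shows. Statements on the series, on what has been measured and on what is new or still open speak of the compounds shown alone.

Compounds measured in a functional assay on RAW264.7 cells (Mus musculus) for inhibition, read by ELISA, with a stated time of 24 h; a higher number here means that more compound is needed for the effect, a lower number that less compound is needed:
compound 1 `CC/C=C\CC1C(=O)C=CC1CC(=O)OC` gives 19000 nM;
compound 2 `CC/C=C\C[C@H]1C(=O)C=C[C@H]1CC(=O)OCCCCC` gives 25000 nM;
compound 3 `CC/C=C\C[C@H]1C(=O)C=C[C@H]1CC(=O)Oc1ccc(O)cc1` gives 23000 nM.

Compound 2 stands at the top edge of these three numbers, yet the three values lie within the usual scatter of one another: the step of a 1.1-fold lower number from compound 2 to compound 3 (0.04 log units; within the scatter) is within the scatter, and the value of compound 1 in this assay differs from that of compound 2 by no more than the scatter either. Compound 4 `CC/C=C\C[C@H]1C(=O)C=C[C@H]1CC(=O)OCCOCCOCCOC` differs from compound 2 by 2-(2-methoxyethoxy)ethoxy in place of propyl on a saturated chain carbon, two bonds along the chain from an oxygen next to a carbonyl group.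

Two comparisons bear on this change. The step from compound 2 to compound 3 replaces the group on the ester oxygen and leaves the number unchanged within the scatter, and compounds 1 and 2, which differ in the ester group as well, also give values within the scatter of each other. Both show that the ester substituent has not moved the number in this assay among the measured compounds. Compound 4 is therefore expected to give 24000 nM, with a range from 10000 nM to 60000 nM. The step from compound 2 to compound 4 is estimated as a 1.0-fold lower number from compound 2 to compound 4 (0.02 log units; within the scatter), not beyond the scatter.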

Compound 4, half-maximal effective concentration: 35000 nM
The estimate for compound 4 lay 1.5-fold (0.16 log units) below the measured number; the measured number falls inside the stated range.
By their numbers in this assay, from the lowest: compounds 1, 3, 2 and 4 (each within the scatter of the next).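

In this assay, exchanging propyl for 2-(2-methoxyethoxy)ethoxy on a saturated chain carbon, two bonds along the chain from an oxygen next to a carbonyl group, gives a 1.4-fold higher number from compound 2 to compound 4 (0.15 log units; within the scatter). This place therefore accepts a group of 8 heavy atoms in place of one of 3, carrying 3 hydrogen-bond acceptors where propyl has none, without the number leaving the scatter, a change that goes further than the exchange of pentyl for 4-hydroxyphenyl between compound 2 and compound 3. No measurement is available that explains this result.

Going by these compounds, whether any group on this ester oxygen can move the number beyond the scatter remains open. A terminal amine or carboxylic acid on the chain could test this, and an amide in place of the ester would test the link itself.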